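Amide substituent changes on the shared core

The compounds below may be only part of what the source reports. "The series", "measured", "known", "first", "only" and "open" are said of these compounds alone.

Measured compounds in a functional assay on BXPC-3 cells (Homo sapiens) for antiproliferative activity, read by MTT assay, with a stated time of 24 h; on this read-out lower numbers stand for stronger inhibition and higher numbers for weaker inhibition:
compound 1, `CCn1c(C(=O)NCC(=O)OC)ccc1C(CC)(CC)c1ccc(OCS(=O)(=O)c2ccccc2)c(C)c1`, gives 20000 nM.
compound 2, `CCn1c(C(=O)NCCNC(=O)OC(C)(C)C)ccc1C(CC)(CC)c1ccc(OCS(=O)(=O)c2ccccc2)c(C)c1`, gives only a limit of the assay, > 50000 nM.
compound 3, `CCn1c(C(=O)NC(C)(C)CO)ccc1C(CC)(CC)c1ccc(OCS(=O)(=O)c2ccccc2)c(C)c1`, gives 18300 nM.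

Compound 2 stands at the weak end of these three, and its result is a limit and not a number, as noted by the limit of > 50000 nM in this assay, at which 1 of the 3 values shown sits. The step from compound 1 reads an at least 2.5-fold higher number from compound 1 to compound 2 (0.39 log units; beyond the scatter), and the step onward to compound 3 reads an at least 2.7-fold lower number from compound 2 to compound 3 (0.43 log units; beyond the scatter). Between compound 1 and compound 3 the change is a 1.1-fold lower number from compound 1 to compound 3 (0.04 log units; within the scatter), so those two sit together.

Compound 4, `CCn1c(C(=O)N[C@@H](CO)CCO)ccc1C(CC)(CC)c1ccc(OCS(=O)(=O)c2ccccc2)c(C)c1`, is not yet measured. Its difference from compound 2: 3-hydroxy-1-(hydroxymethyl)propyl in place of 2-((tert-butoxycarbonyl)amino)ethyl on an amide-type nitrogen. The step that bears on it most is an at least 2.7-fold lower number from compound 2 to compound 3 (0.43 log units; beyond the scatter), where the 2-((tert-butoxycarbonyl)amino)ethyl group also left and the 1-(hydroxymethyl)-1-methylethyl group entered. The change from compound 1 to compound 3, a 1.1-fold lower number from compound 1 to compound 3 (0.04 log units; within the scatter), shows that the 1-(hydroxymethyl)-1-methylethyl and (methoxycarbonyl)methyl groups give numbers within the scatter of each other. A lower number in this assay is therefore expected for compound 4, by a modest step, an at least 2.5-fold lower number from compound 2 to compound 4 (0.39 log units; beyond the scatter). Compound 4 is estimated at 20000 nM, in a range of 8000 nM to 50000 nM, with a real chance that the result is again only a limit.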

Compound 4, half-maximal inhibitory concentration: > 50000 nM
Compound 4: only a limit was reported; the forecaster's own chance of this, stated with the estimate: 25%; middle value at least 2.5-fold (0.39 log units) from the limit.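

In this assay, 3-hydroxy-1-(hydroxymethyl)propyl in place of 1-(hydroxymethyl)-1-methylethyl on the amide-type nitrogen gives an at least 2.7-fold higher number from compound 3 to compound 4 (0.43 log units; beyond the scatter), and the same group in place of (methoxycarbonyl)methyl gives an at least 2.5-fold higher number from compound 1 to compound 4 (0.39 log units; beyond the scatter). Loss of the 2-((tert-butoxycarbonyl)amino)ethyl group therefore does not by itself bring a readable value, and the hydroxyl-bearing substituents of compound 3 and compound 4 do not read alike at this position. The step from compound 2 to compound 4 cannot be read, since both of its ends are limits and not numbers: the limit of > 50000 nM in this assay, at which 2 of the 4 values shown sit.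

As far as these compounds go, how far compound 2 and compound 4 lie past that limit, and whether they differ from each other at all, stays unknown. Also open, from the compounds shown here alone, is whether a primary amine or a carboxylic acid on the amide-type nitrogen, or a longer chain ending in a single hydroxyl, would read with compound 3 or with compound 4, and whether the mirror-image form of the 3-hydroxy-1-(hydroxymethyl)propyl group would read the same.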